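Removing the aromatic chloro: expected whole-animal toxicity

A few compounds are considered here, and "the series" means these few. Any claim that something is new, unique, unknown or untested is made for them only; others in the source may bear on it.

Three compounds share one core and have been tested in a toxicity assay on the whole organism (strain Icem-CET (SPF Caw)) for cytotoxicity, with Mus musculus as the target; on this read-out higher numbers stand for an effect only at larger amounts of compound and lower numbers for an effect already at smaller amounts:
Compound 1, `C=CCNC(=O)/C(C)=C(\C)c1ccc(Br)cc1`, gives 500 mg/kg.
Compound 2, `C=CCNC(=O)/C(C)=C(\C)c1ccc(C)cc1`, gives 150 mg/kg.
Compound 3, `C=CCNC(=O)/C(C)=C(\C)c1ccc(Cl)cc1`, gives 70 mg/kg.

Compound 3 stands lowest of the three in this assay, so its effect appears at the smallest amount of compound. Two measured steps lead down to it: a 7.1-fold lower number from compound 1 to compound 3 (0.85 log units; beyond the scatter) and a 2.1-fold lower number from compound 2 to compound 3 (0.33 log units; beyond the scatter). A third step, a 3.3-fold lower number from compound 1 to compound 2 (0.52 log units; beyond the scatter), shows that swapping one group for another at the same place moves the number by a modest amount as well. Compound 4, `C=CCNC(=O)/C(C)=C(\C)c1ccccc1`, differs from compound 3 in one place: hydrogen in place of chloro on an aromatic carbon. For the measured compounds named here, no measured step removes the group at this place entirely, so the three known steps only show that exchanging it shifts the number modestly and that chloro holds the lowest number among them. Compound 4 is therefore expected to lie higher, by the step of a 2.1-fold higher number from compound 3 to compound 4 (0.33 log units; beyond the scatter). Compound 4 is estimated at 150 mg/kg, with a range from 50 mg/kg to 500 mg/kg.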

Compound 4, dose for half-maximal effect: 250 mg/kg
For compound 4 the middle estimate is 1.7-fold (0.22 log units) below the measured one; measured number inside the range.
By their numbers in this assay, from the lowest: compound 3; then compounds 2, 4 and 1 (each within the scatter of the next, the first and the last beyond it).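

Hydrogen at this place gives the series a baseline with no substituent, and in (this assay) the chloro stands apart from it (a 3.6-fold higher number from compound 3 to compound 4 (0.55 log units; beyond the scatter)). The other two exchanges stay within the scatter (a 1.7-fold higher number from compound 2 to compound 4 (0.22 log units; within the scatter); a 2.0-fold lower number from compound 1 to compound 4 (0.30 log units; within the scatter)), so neither methyl nor bromo can be told apart from hydrogen here, and among these groups only chloro shifts the number clearly from the unsubstituted compound. No supporting data accompany this result to explain why chloro behaves differently.

The compounds shown leave open whether fluoro, an amine or a carboxylic acid on this aromatic carbon would fall with chloro or with hydrogen. They also leave open whether replacing chloro with hydrogen would produce a similar step on a different core.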